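The source may report more compounds than this note shows. Statements on the series, on what has been measured and on what is new or still open speak of the compounds shown alone.

Measured compounds:
- compound 1, `CNC(=O)c1c(NO)cc(-c2ccc(C)cc2)oc1=O`: > 20000 nM
- compound 2, `O=C(NCCO)c1c(NO)cc(-c2ccc(Cl)cc2)oc1=O`: > 20000 nM

The account follows a pair of hydroxyamino-substituted pyranone amides and one untested relative. In an ADME assay on Huh-7 cells (Homo sapiens) for cytotoxicity, read by a luciferase reporter and WST assay, with a stated time of 3 days (on this read-out higher numbers stand for lower toxicity in this test and lower numbers for higher toxicity in this test), compound 1 gives > 20000 nM, which is a limit of the assay rather than a number. In this assay compound 2 gives > 20000 nM, again a limit and not a measured value. Compound 2 therefore stands at the limit of > 20000 nM in this assay, at which 2 of the 2 values shown sit, together with compound 1; neither compound shows a numeric half-maximal cytotoxic concentration, so no ordering between them can be drawn.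

Compound 3, `Cc1ccc(-c2cc(NO)c(C(=O)NCCO)c(=O)o2)cc1`, differs from compound 2 by methyl in place of chloro on an aromatic carbon, the same change that separates compound 1 from compound 2 at the aryl ring, while the hydroxyethyl amide of compound 2 is kept. Among the compounds with values here, no step between measured compounds is available to size this change. Given that compound 1 with the methylphenyl group already sits at the same limit as compound 2, compound 3 is expected to show no step beyond the scatter, a step that the limit leaves unreadable from compound 2 to compound 3, and is estimated at 30000 nM (15000 nM to 100000 nM), most likely reported as a limit as well.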

Compound 3, half-maximal cytotoxic concentration: > 20000 nM
Compound 3 was reported as a limit; the forecaster's own chance of this, stated with the estimate: 85%; the middle value does not contradict the limit.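

No step can be read among compound 1, compound 2 and compound 3 in this assay, because all three stand at the same limit of the assay: the limit of > 20000 nM in this assay, at which 3 of the 3 values shown sit.

The compounds shown leave open how far their half-maximal cytotoxic concentrations lie from one another, and whether methyl in place of chloro or the change in the amide chain makes any difference.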